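From a Carboxyphenyl to a Bromophenyl Amide

The source may hold more compounds than are shown below. What is called first, only, known or untested is meant among the compounds shown, and "the series" means these compounds.

Among the compounds with values here, in an ADME assay on MT4 cells (Homo sapiens) for cytotoxicity, read by MTT assay, with a stated time of 5 days (a higher number here means that more compound is tolerated, a lower number that less compound is tolerated), compound 1 `Cc1cc(C)cc(S(=O)(=O)n2c(SCC(=O)Nc3ccc(C(=O)O)cc3)nc3ccccc32)c1` gives 115000 nM as the only exact number so far. Compound 2 `Cc1cc(C)cc(S(=O)(=O)n2c(OCC(=O)Nc3ccc(S(C)(=O)=O)cc3Cl)nc3ccccc32)c1` shows > 228000 nM as its reading, which is a limit of the assay and not a number. Compound 1 therefore cannot be ranked against an exact neighbour, and it serves as the single anchor for what follows.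

The next compound is compound 3 `Cc1cc(C)cc(S(=O)(=O)n2c(SCC(=O)Nc3ccccc3Br)nc3ccccc32)c1`, which keeps the core of compound 1 and differs in one place (2-bromophenyl in place of 4-carboxyphenyl on an amide-type nitrogen). There, 2-bromophenyl stands in place of 4-carboxyphenyl on an amide-type nitrogen. Within the data shown here, no measured pair of close relatives shows how large a swap of this kind tends to be, so any forecast is tentative and its range must stay wide.

A moderate drop is expected, meaning that somewhat less compound would be tolerated, and the estimated change is a 2.9-fold lower number from compound 1 to compound 3 (0.46 log units; beyond the scatter) in this assay on this reasoning. For compound 3 the estimate is 40000 nM (expected range 10000 nM to 150000 nM).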

Compound 3, half-maximal cytotoxic concentration: >= 235000 nM
Compound 3: only a limit was reported (the forecaster's own chance of this, stated with the estimate: 25%); middle value at least 5.8-fold (0.76 log units) away from the limit.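

Placing 2-bromophenyl in place of 4-carboxyphenyl on the amide-type nitrogen gives an at least 2.0-fold higher number from compound 1 to compound 3 (0.31 log units; beyond the scatter) in this assay, so in this one pair the change goes towards more compound being tolerated. Within the data shown here, compound 1 and compound 2 formed no pair differing in one place, which makes this the first view of this position: the 4-carboxyphenyl group can be replaced here with no drop in the number. The reading for compound 3 is a limit of the assay and not a number, so the step has a known minimum but no known full size: the limit of >= 235000 nM in this assay, at which 1 of the 3 values shown sits.

The change removes the carboxylic acid and brings in a bromine at the same time, and these compounds cannot separate the two, whereas a plain phenyl group on the same nitrogen would show what each contributes. As far as these compounds go, whether an amine on that ring would give a reading closer to compound 1 or to compound 3 also stays open, as does whether this swap would behave the same way in a compound with a different core.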